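The compounds below may be only part of what the source reports. "The series", "measured", "known", "first", "only" and "open" are said of these compounds alone.

In an ADME assay on the whole organism (plasma, Rattus norvegicus) for metabolic stability, read by LC-MS, at a dose of 0.1 mg/kg by the intravenous route (a higher number here means that the compound lasts longer, a lower number that the compound disappears faster), compound 1 (`Cc1cnc(Oc2cc(Cl)c(F)c(-c3ccc4c(c3)CC[C@H](CCC(=O)O)O4)c2)s1`) gives 0.93 h and compound 3 (`O=C(O)CC[C@H]1CCc2cc(-c3cc(OC(F)(F)F)ccc3F)ccc2O1`) gives 1.3 h within the scatter of each other. Compound 2 (`COc1cc(O[C@H]2C[C@H](OC)C2)nc(-c2ccc3c(c2)CC[C@H](CCC(=O)O)O3)c1F`) gives 2.4 h and stands beyond the scatter above compound 1. Compound 4 (`COc1cc(Oc2ncc(C)s2)cc(-c2ccc3c(c2)CC[C@H](CCC(=O)O)O3)c1F`) is still unmeasured and differs from compound 1 by methoxy in place of chloro on an aromatic carbon, ortho to a fluoro group (methoxy in place of chloro on an aromatic carbon). Among the compounds with values here, no measured pair differs in one place only, so nothing measured sizes this change, and no shift beyond the scatter is expected in this assay here. The estimated step (a 1.3-fold higher number from compound 1 to compound 4 (0.11 log units; within the scatter)) stays within the scatter. For compound 4 the estimated half-life is 1.2 h with an expected range from 0.6 h to 2.4 h around it.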

Compound 4, half-life: 1.2 h
For compound 4 middle estimate and measured number coincide at the digits printed; low and high end bracket the measured number.
By their numbers in this assay, from the lowest: compounds 1, 4, 3 and 2 (each within the scatter of the next, the first and the last beyond it).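

In this assay, chloro and methoxy on this aromatic carbon, ortho to a fluoro group, form the only one-place pair shown, with a 1.3-fold higher number from compound 1 to compound 4 (0.11 log units; within the scatter). At this position, methoxy in place of chloro therefore leaves the half-life with no shift that can be told from the scatter. Nothing on hand gives a reason for this result. From the compounds shown here alone, whether an amine, a nitrile or a longer alkoxy chain on this carbon would behave alike stays open. Also open, going by these compounds, is whether the change holds when another group replaces the (5-methyl-1,3-thiazol-2-yl)oxy group.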